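The source may hold more compounds than are shown below. What is called first, only, known or untested is meant among the compounds shown, and "the series" means these compounds.

Compound 1 `O=C(Nc1cc(-c2ccccc2)nn1-c1ccccc1)c1ccccc1` gives 203 nM in a functional assay on cells for positive allosteric modulation of metabotropic glutamate receptor 5 (Rattus norvegicus), read by calcium flux; on this read-out lower numbers stand for an effect already at smaller amounts and higher numbers for an effect only at larger amounts of compound.
Compound 2 `COc1cccc(C(=O)Nc2cc(-c3ccccc3)nn2-c2ccccc2)c1` gives 102 nM in this assay.
Compound 3 `COc1cc(OC)cc(C(=O)Nc2cc(-c3ccccc3)nn2-c2ccccc2)c1` gives 2040 nM in this assay.

All three compounds share one core and differ only in the group on the carbonyl carbon. Compound 3 stands with the highest number of the three: the step of a 10-fold higher number from compound 1 to compound 3 (1.00 log units; beyond the scatter) and the step of a 20-fold higher number from compound 2 to compound 3 (1.30 log units; beyond the scatter) both go beyond the scatter, while the step of a 2.0-fold lower number from compound 1 to compound 2 (0.30 log units; within the scatter) stays within it.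

Compound 4 `O=C(Nc1cc(-c2ccccc2)nn1-c1ccccc1)C1CCCCC1` has not been measured. Its difference from compound 3 is cyclohexyl in place of 3,5-dimethoxyphenyl on a carbonyl carbon. Among the compounds with values here, no measured step swaps an aromatic ring for a non-aromatic one, so the bearing of the measured steps is indirect. What they do show is that the two methoxy groups of compound 3 go with a higher number than the plain phenyl of compound 1, which cyclohexyl also lacks. Compound 4 is therefore expected to give a lower number than compound 3 in this assay, by a step around a 4.1-fold lower number from compound 3 to compound 4 (0.61 log units; beyond the scatter), though the size of that step is uncertain. The estimate for compound 4 is 500 nM, with a range from 100 nM to 3000 nM.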

Compound 4, half-maximal effective concentration: > 10000 nM
Compound 4: no number, only a limit; the forecaster's own chance of this, stated with the estimate: 20%; middle value at least 20-fold (1.30 log units) from the limit.
By their numbers in this assay, from the lowest: compounds 2 and 1 (each within the scatter of the next); then compound 3. At a limit, above all of these: compound 4.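

Compound 4 gives only a limit in this assay, not a number, so each step to it is a minimum size: the limit of > 10000 nM in this assay, at which 1 of the 4 values shown sits.

The earlier compounds shown here varied only the groups carried on an aromatic ring at this carbonyl carbon, whereas this change replaces the aromatic ring itself with a non-aromatic ring of the same size. The most direct comparison is with the plain phenyl, an at least 49-fold higher number from compound 1 to compound 4 (1.69 log units; beyond the scatter), and the steps from the two methoxy-bearing compounds run the same way, an at least 98-fold higher number from compound 2 to compound 4 (1.99 log units; beyond the scatter) and an at least 4.9-fold higher number from compound 3 to compound 4 (0.69 log units; beyond the scatter). So at this position, an aromatic ring goes with far lower numbers than cyclohexyl, and even the 3,5-dimethoxyphenyl, the highest number among the earlier compounds, stays on the lower side of cyclohexyl.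

With cyclohexyl as the only non-aromatic group shown, it remains open how a piperidine ring, which brings an amine, or a longer chain such as butyl would behave on this carbonyl carbon. On these data alone, it also remains open whether a pyridine ring, or a phenyl carrying fluorine or chlorine instead of methoxy, would stay with the lower numbers of compound 1 and compound 2.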